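The source may report more compounds than this note shows. Statements on the series, on what has been measured and on what is new or still open speak of the compounds shown alone.

Compound 1 `O=C1C2=C(C(=O)c3ncccc31)C1(CS2)NC(=O)N(c2ccc([N+](=O)[O-])cc2)C1=O`: 100 nM
Compound 2 `O=C1NN(c2ccc([N+](=O)[O-])cc2)C(=O)C2(CSC3=C2C(=O)c2ncccc2C3=O)N1`: 650 nM

For the measured compounds named here, in a functional assay on ACHN cells (Homo sapiens) for antiproliferative activity, read by MTT assay, with a stated time of 96 h (a higher number here means a weaker inhibitor, a lower number a stronger inhibitor), compound 1 gives 100 nM, the lowest of the two numbers so far. Compound 2 gives 650 nM, and the gap between the two lies beyond the usual scatter. Compound 3 `CC(C)(C)c1ccc(N2C(=O)NC3(CSC4=C3C(=O)c3ncccc3C4=O)C2=O)cc1` has not yet been tested in this assay. It differs from compound 1 in one place: tert-butyl in place of nitro on an aromatic carbon. Going by the values given here, no measured pair shows this same change, so its effect is open. A modest weakening is expected for compound 3, the step of a 2.5-fold higher number from compound 1 to compound 3 (0.40 log units; beyond the scatter) perhaps no larger than the scatter itself. Compound 3 is therefore estimated at 250 nM, within a range from 60 nM to 1200 nM.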

Compound 3, half-maximal inhibitory concentration: 150 nM
Beside the measured number, compound 3's estimate is 1.7-fold (0.22 log units) above it, within the range that was stated.
By their numbers in this assay, from the lowest: compounds 1 and 3 (each within the scatter of the next); then compound 2.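

Changing nitro to tert-butyl on this aromatic carbon, para to a large group, gives a 1.5-fold higher number from compound 1 to compound 3 (0.18 log units; within the scatter) in this assay and so stays within the scatter. The position therefore tolerates a group of carbon alone, with no hydrogen-bond acceptors, as well as it does nitro, so those acceptors are not needed here to keep a number of this size. On these data alone, whether an amine, a carboxylic acid or a longer alkyl chain would do the same at this position remains open. Nothing measured here gives a reason for this result.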